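The source may hold more compounds than are shown below. What is called first, only, known or untested is meant among the compounds shown, and "the series" means these compounds.

Measured compounds:
compound 1 `Cc1ccc2nc(Nc3nc(Nc4ccc(S(C)(=O)=O)cc4)ncc3F)sc2c1` — > 50000 nM
compound 2 `COc1cccc(Nc2ncc(C)c(Nc3nc4ccccc4s3)n2)c1` — > 50000 nM

In a functional assay on PC-3 cells (Homo sapiens) for antiproliferative activity, read by MTT assay, with a stated time of 48 h (on this read-out lower numbers stand for stronger inhibition and higher numbers for weaker inhibition), compound 1 gives only a limit, > 50000 nM. In this assay compound 2 likewise gives only a limit, > 50000 nM. Within the data shown here, both values shown sit at the limit of > 50000 nM in this assay, at which 2 of the 2 values shown sit, so compound 2 stands at the limit of the assay and no measured step exists in the set. Compound 3 `Cc1cnc(Nc2cccc(F)c2)nc1Nc1nc2ccccc2s1` differs from compound 2 by fluoro in place of methoxy on an aromatic carbon. Among the measured compounds shown here, with no measured step to go by, no change beyond the scatter is expected, and a further limit is the likeliest outcome. Compound 3 is expected at 60000 nM, within 25000 nM to 200000 nM. The implied step that the limit leaves unreadable from compound 2 to compound 3 is expected to be none beyond the scatter.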

Compound 3, half-maximal inhibitory concentration: > 50000 nM
Compound 3: no number, only a limit; the forecaster's own chance of this, stated with the estimate: 80%; the middle value does not contradict the limit.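

No step can be read between compound 2 and compound 3 in this assay, because both give only a limit: the limit of > 50000 nM in this assay, at which 3 of the 3 values shown sit.

The compounds shown leave open how compound 2 and compound 3 compare in this assay, and whether any close analogue gives a number there.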